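Working notes on compound 1 and the step to compound 4

The compounds below may be only part of what the source reports. "The series", "measured", "known", "first", "only" and "open" are said of these compounds alone.

Compound 1 `CCCCc1ccc(-c2cc(-c3cn([C@H]4C[C@H](OC(C)=O)[C@@H](COC(C)=O)O4)c(=O)[nH]c3=O)on2)cc1` gives 3000 nM in an ADME assay on Vero cells (Chlorocebus sabaeus) for cytotoxicity; a higher number here means that more compound is tolerated, a lower number that less compound is tolerated. Compound 2 `CCCCCc1cc(-c2cn([C@H]3C[C@H](OC(C)=O)[C@@H](COC(C)=O)O3)c(=O)[nH]c2=O)on1` gives 3000 nM in this assay, and compound 3 `CCc1ccc(-c2cc(-c3cn([C@H]4C[C@H](OC(C)=O)[C@@H](COC(C)=O)O4)c(=O)[nH]c3=O)on2)cc1` gives 3000 nM in this assay. The steps of no change at the digits printed from compound 1 to compound 2 (within the scatter) and no change at the digits printed from compound 2 to compound 3 (within the scatter) exchange the whole group on an aromatic carbon of the shared core, while no change at the digits printed from compound 1 to compound 3 (within the scatter) trims a chain on the six-membered aromatic ring of carbon only; none of the three moves the half-maximal cytotoxic concentration beyond the scatter, so compound 1 stands level with compounds 2 and 3 on the numbers shown.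

Compound 4 `CC(=O)OC[C@H]1O[C@@H](n2cc(-c3cc(-c4ccc(C(C)C)cc4)no3)c(=O)[nH]c2=O)C[C@@H]1OC(C)=O` is not yet measured. Its difference from compound 1: isopropyl in place of butyl on an aromatic carbon. For the measured compounds named here, the measured steps that bear on it are all three, as each alters the substituent at that end of the molecule and none produced a change beyond the scatter; the closest relative is the trimming of a chain on the same ring in compound 3, and no measured step exchanges butyl for isopropyl directly. The expectation is therefore no step beyond the scatter in this assay, expressed as no change at the digits printed from compound 1 to compound 4 (within the scatter). Compound 4 is estimated at 3000 nM, with a range from 1500 nM to 6000 nM.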

Compound 4, half-maximal cytotoxic concentration: 3000 nM
Estimate against measurement, compound 4: no gap at the digits printed; the measured number falls inside the stated range.
By their numbers in this assay, from the lowest: compounds 1, 2, 3 and 4 (each within the scatter of the next).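

In this assay, for the compounds shown here, the isopropyl group brings a branched end to the six-membered aromatic ring of carbon only for the first time, para to a large group, and the exchange for butyl gives no change at the digits printed from compound 1 to compound 4 (within the scatter), while the comparison with the ethyl-bearing analogue gives no change at the digits printed from compound 3 to compound 4 (within the scatter). Replacing pentyl with the whole 4-isopropylphenyl group on an aromatic carbon gives no change at the digits printed from compound 2 to compound 4 (within the scatter), so among these four compounds neither branching nor the exchange between this aryl group and the straight chain takes the half-maximal cytotoxic concentration beyond the scatter, and no compound goes against that reading. Nothing at hand bears on why these values coincide.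

On these data alone, all four compounds carry only hydrocarbon groups at this end of the molecule, so it remains open how an amine, a carboxylic acid or a hydroxyl group at the same place would read in this assay. As far as these compounds go, a much longer chain such as decyl at this position, and a core without the two acetate esters, also remain open.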